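The source may report more compounds than this note shows. Statements on the series, on what has been measured and on what is new or still open speak of the compounds shown alone.

Compound 1 `Cc1ccc(S(=O)(=O)/N=C(/CCNC2=CC(=O)c3ccccc3C2=O)Nc2ccccc2[N+](=O)[O-])cc1` is one of three close relatives that share a core and differ only in the group carried on an amine nitrogen. In a functional assay on DU-145 cells (Homo sapiens) for cytotoxicity, read by MTT assay, with a stated time of 48 h (a higher number here means a weaker inhibitor, a lower number a stronger inhibitor), compound 1 gives 7590 nM, the lowest of the three numbers, though none of the others sits beyond the scatter from it. Compound 2 `Cc1ccc(S(=O)(=O)/N=C(/CCNC2=CC(=O)c3ccccc3C2=O)Nc2cc(F)c(F)c(F)c2)cc1` carries 3,4,5-trifluorophenyl on that nitrogen and gives 12600 nM in this assay, a step of a 1.7-fold higher number from compound 1 to compound 2 (0.22 log units; within the scatter). Compound 3 `Cc1ccc(S(=O)(=O)/N=C(/CCNC2=CC(=O)c3ccccc3C2=O)NCc2ccccc2)cc1` carries benzyl there and gives 9120 nM, a step of a 1.2-fold higher number from compound 1 to compound 3 (0.08 log units; within the scatter); between compound 2 and compound 3 the step is a 1.4-fold lower number from compound 2 to compound 3 (0.14 log units; within the scatter).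

Compound 4 `Cc1ccc(S(=O)(=O)/N=C(/CCNC2=CC(=O)c3ccccc3C2=O)NC2CCCCC2)cc1` changes the same position again: cyclohexyl in place of 2-nitrophenyl on an amine nitrogen

The two measured steps that bear on this, 2-nitrophenyl to 3,4,5-trifluorophenyl and 2-nitrophenyl to benzyl, both stay within the scatter, so a swap at this nitrogen to cyclohexyl is expected to move the number little in either direction. For compound 4 in this assay the expected value is 9000 nM, with a range from 4000 nM to 20000 nM, a step of a 1.2-fold higher number from compound 1 to compound 4 (0.07 log units; within the scatter) that is expected to stay within the scatter.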

Compound 4, half-maximal inhibitory concentration: 16600 nM
Compound 4: the middle estimate sits 1.8-fold (0.27 log units) below what was measured; the measured number falls inside the stated range.
By their numbers in this assay, from the lowest: compounds 1, 3, 2 and 4 (each within the scatter of the next, the first and the last beyond it).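

Within the data shown here, this is the first change at this nitrogen to pass the scatter, with a 2.2-fold higher number from compound 1 to compound 4 (0.34 log units; beyond the scatter) as a modest step, and it replaces an aromatic ring bearing a nitro group with a non-aromatic ring of carbon only. The same cyclohexyl group stays within the scatter of the other two groups, with a 1.8-fold higher number from compound 3 to compound 4 (0.26 log units; within the scatter) and a 1.3-fold higher number from compound 2 to compound 4 (0.12 log units; within the scatter) as its steps, so in this assay only compound 1 and compound 4 can be told apart, and a non-aromatic ring on this nitrogen still gives a measurable number. Nothing shown here accounts for the step from compound 1 to compound 4, so its cause remains unknown.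

Compound 1 and compound 4 differ in both the ring and the nitro group, and a plain phenyl group on this nitrogen would help separate those two parts of the change. Also open, on these data alone, is how an open chain such as butyl, or a cyclohexyl group carrying a carboxylic acid, would read in this assay at this position.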